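The source may report more compounds than this note shows. Statements on the series, on what has been measured and on what is new or still open speak of the compounds shown alone.

Measured so far:
Compound 1, `CN(C)CCn1cnnc1-c1cc(Oc2ccc(NC(=O)N/N=C/c3c(Cl)cccc3Cl)cc2F)ccn1`: 160 nM
Compound 2, `COc1ccc(/C=N/NC(=O)Nc2ccc(Oc3ccnc(-c4nncn4CCN(C)C)c3)c(F)c2)c(OC)c1OC`: 2020 nM
Compound 3, `Cn1ncnc1-c1cc(Oc2ccc(NC(=O)N/N=C/c3ccccc3)cc2F)ccn1`: a limit, > 100000 nM

All three share one core and differ in the aromatic group attached to the carbon that carries a double bond to nitrogen. In a functional assay on MKN-45 cells (Homo sapiens) for cytotoxicity, read by MTT assay, with a stated time of 72 h (on this read-out higher numbers stand for weaker inhibition and lower numbers for stronger inhibition), compound 2 stands at the highest of the two numbers shown, the weakest inhibition that was actually measured. Its nearest neighbour is compound 1, and the gap between them is the step of a 13-fold higher number from compound 1 to compound 2 (1.10 log units; beyond the scatter), so the aryl group at this position clearly matters. For compound 3 the assay reports only a limit, > 100000 nM, not a number; this is recorded in the limit of > 100000 nM in this assay, at which 1 of the 3 values shown sits.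

Compound 4, `CN(C)CCn1cnnc1-c1cc(Oc2ccc(NC(=O)N/N=C/c3ccc(O)c(O)c3)cc2F)ccn1`, is not yet measured. It differs from compound 2 by 3,4-dihydroxyphenyl in place of 2,3,4-trimethoxyphenyl on a carbon with a double bond to nitrogen. Among the compounds with values here, no measured step compares a dihydroxyphenyl with a trimethoxyphenyl; the only step at this position is the large one from compound 1 to compound 2, which shows how much this group can shift the read-out but not in which direction the present change will go. Compound 4 is therefore expected, with wide uncertainty, to give 3000 nM, somewhere between 700 nM and 15000 nM. The step of a 1.5-fold higher number from compound 2 to compound 4 (0.17 log units; within the scatter) that this estimate means is expected to lie within the scatter.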

Compound 4, half-maximal inhibitory concentration: 3240 nM
Compound 4: the middle estimate sits 1.1-fold (0.03 log units) below what was measured, within the range that was stated.
By their numbers in this assay, from the lowest: compound 1; then compounds 2 and 4 (each within the scatter of the next). At a limit, above all of these: compound 3.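

In this assay, putting 3,4-dihydroxyphenyl in place of 2,3,4-trimethoxyphenyl gives a 1.6-fold higher number from compound 2 to compound 4 (0.21 log units; within the scatter), so a smaller group that carries hydrogen-bond donors, where the departing group had none, cannot be told apart from it on this read-out. Within the data shown here, the only earlier step at this position was a large one. This new step shows that not every change of aromatic group here moves the number. Compound 1 now stands apart from two different oxygen-bearing rings, with a 20-fold higher number from compound 1 to compound 4 (1.31 log units; beyond the scatter) alongside the earlier 13-fold higher number from compound 1 to compound 2 (1.10 log units; beyond the scatter), yet nothing measured here explains what sets its 2,6-dichlorophenyl apart.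

The compounds shown leave open whether the chlorine atoms themselves matter or whether any two groups in those places would do, which a 2,6-dimethylphenyl or a 2,6-difluorophenyl at this position could test. They also leave open whether a ring bearing an amine or a carboxylic acid would stay with compound 2 and compound 4 or move towards compound 1.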